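Removing the Fluoro from a Tertiary Carbinol Growth Inhibitor

A few compounds are considered here, and "the series" means these few. Any claim that something is new, unique, unknown or untested is made for them only; others in the source may bear on it.

Two measured compounds frame this step. Compound 1 `COc1ccc(C(O)(Cc2ccc(F)cc2)c2cccc3ccccc23)c(OC)c1OC` was tested in a functional assay on THP-1 cells (Homo sapiens) for inhibition, read by sulforhodamine B assay, with a stated time of 48 h (a lower number here means a stronger inhibitor, a higher number a weaker inhibitor), and compound 1 gives 5860 nM. Its olefinic relative, compound 2 `COc1ccc(/C(=C/c2ccc(F)cc2)c2cccc3ccccc23)c(OC)c1OC`, gives 18900 nM in this assay. Compound 1 thus stands with the lower of the two numbers, and the gap to compound 2 is beyond the usual scatter of the measurement.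

The next compound, compound 3 `COc1ccc(C(O)(Cc2ccccc2)c2cccc3ccccc23)c(OC)c1OC`, is drawn from compound 1 by a single change: hydrogen in place of fluoro on an aromatic carbon. Within the data shown here, no pair of measured compounds shows what this change does on its own, so there is no measured step to lean on. A single fluorine on an aromatic carbon is a small change, and in this assay the expectation is a step from compound 1 to compound 3 of a 1.3-fold higher number from compound 1 to compound 3 (0.11 log units; within the scatter), which is expected to lie within the scatter or only just beyond it, leaning toward a slightly weaker inhibitor.

On that basis compound 3 is estimated to give about 7500 nM in this assay, with a plausible range from 3000 nM to 18000 nM.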

Compound 3, half-maximal inhibitory concentration: 12400 nM
Beside the measured number, compound 3's estimate is 1.7-fold (0.22 log units) below it, within the range that was stated.
By their numbers in this assay, from the lowest: compound 1; then compounds 3 and 2 (each within the scatter of the next).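

Among these compounds, this is the first direct reading of the change: in this assay, replacing fluoro with hydrogen on an aromatic carbon, para to a large group, gives a 2.1-fold higher number from compound 1 to compound 3 (0.33 log units; beyond the scatter). The step is modest, but it shows that the fluoro at this place has a measurable bearing on the read-out, with compound 1, the compound that carries it, being the stronger inhibitor of this pair. Nothing available explains why going from 4-fluorobenzyl to benzyl moves the number in this direction.

The compounds shown leave open whether another group on this same aromatic carbon, such as chloro, methoxy or a nitrile, would match the fluoro or move the number further in either direction. They also leave open whether the same exchange of fluoro for hydrogen would produce a step of similar size on the olefinic compound 2, whose own partner without the fluoro does not stand among them.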